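Oral series: glycinamide esters around one core

The source may report more compounds than this note shows. Statements on the series, on what has been measured and on what is new or still open speak of the compounds shown alone.

Measured so far:
compound 1 `CC(C)[C@H](NC(=O)CN(c1nc(Cl)nc2[nH]cnc12)C1CC1)C(=O)OCc1ccccc1` — 55.5%
compound 2 `O=C(CN(c1ncnc2c1ncn2C1CCCCO1)C1CC1)NCC(=O)OCc1ccccc1` — 40.4%
compound 3 `O=C(OCc1ccccc1)[C@@H]1CCCN1C(=O)CN(c1ncnc2c1ncn2C1CCCCO1)C1CC1` — 36.7%

All three have been run in a functional assay on the whole organism (Tail, strain ICR) with Mus musculus as the target, in the tail flick test, with a stated time of 60 min, at a dose of 25 umol/kg by the oral route; on this read-out lower numbers stand for a weaker effect and higher numbers for a stronger effect at the one dose given. Compound 1 gives 55.5% in this assay. Compound 2 gives 40.4% in this assay, and compound 3 gives 36.7% in this assay. Compound 2 sits beneath compound 1 by a gap beyond the scatter, while compound 2 and compound 3 lie within the scatter of each other, so no order between those two can be read from the numbers. For the measured compounds named here, no pair of measured compounds differs in a single place, so no single change has yet been tied to a step.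

Compound 4 `O=C(CN(c1ncnc2c1ncn2C1CCCCO1)C1CC1)N[C@@H](CC(=O)OCc1ccccc1)C(=O)OCc1ccccc1` is the next to be measured in this assay. Relative to compound 2 the change is (benzyloxycarbonyl)methyl in place of hydrogen on a saturated chain carbon bound to an amide-type nitrogen and a carbonyl carbon. Nothing measured isolates the effect of such an addition on this core. The working expectation is that the step from compound 2 to compound 4 stays small, the estimate being a number 2.4 percentage points lower from compound 2 to compound 4 (within the scatter), with no change beyond the scatter anticipated in either direction. Compound 4 is therefore expected to give about 38% in this assay, with a range from 20% to 56%.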

Compound 4, a percentage reported as activity, at one dose (the size of the read-out at that dose, not a potency): 38.2%
For compound 4 the middle estimate is 0.2 percentage points below the measured one, within the range that was stated.
By their numbers in this assay, from the lowest: compounds 3, 4 and 2 (each within the scatter of the next); then compound 1.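

Notes on the added group: in this assay, the first step that can be read at a single place is a number 2.2 percentage points lower from compound 2 to compound 4 (within the scatter). At this saturated chain carbon bound to an amide-type nitrogen and a carbonyl carbon, (benzyloxycarbonyl)methyl in place of hydrogen therefore adds 11 heavy atoms, one six-membered aromatic ring of carbon only and 2 hydrogen-bond acceptors without a change beyond the scatter at the one oral dose given. No measurement shown bears on the reason for this result.

Only one group at this carbon is shown, so it remains open whether methyl, carboxymethyl or a longer chain ending in a benzyl ester would also stay within the scatter of compound 2. As far as these compounds go, the steps involving compound 1 and compound 3 cannot be read, as neither differs from another compound here in a single place, so the shared core and the other parts of the amino acid ester remain untested by single changes.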